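The source may report more compounds than this note shows. Statements on the series, on what has been measured and on what is new or still open speak of the compounds shown alone.

Three galloyl glucosides have so far been measured in a functional assay, read by spectrophotometry, with a stated time of 30 min, tested at 40 uM; a higher number here means a stronger effect of the compound at the concentration tested, a lower number a weaker effect. Compound 1 `CC1=CC[C@@H](C(C)(C)O[C@@H]2O[C@H](COC(=O)c3cc(O)c(O)c(O)c3)[C@@H](O)[C@H](O)[C@H]2O)CC1` gives 95.4% in this assay. Compound 2 `CC1=CC[C@H](C(C)(C)O[C@@H]2O[C@H](COC(=O)c3cc(O)c(O)c(O)c3)[C@@H](O)[C@H](O)[C@H]2O)CC1` gives 95.3% in this assay; its number is the lowest of the three shown, but compound 1 lies nearest and compound 3 furthest, both within the scatter. Compound 3 `C=CCc1cc(OC)c(O)c(O[C@@H]2O[C@H](COC(=O)c3cc(O)c(O)c(O)c3)[C@@H](O)[C@H](O)[C@H]2O)c1` gives 95.7% in this assay.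

Among the measured compounds shown here, the single measured step, a number 0.1 percentage points lower from compound 1 to compound 2 (within the scatter), lies within the scatter, and the fact that compounds 1 and 2 differ only in the configuration as drawn is the only structural point recorded for it. It says nothing about swapping the aglycone, which is what distinguishes compound 4 `C=CCc1ccc(O[C@@H]2O[C@H](COC(=O)c3cc(O)c(O)c(O)c3)[C@@H](O)[C@H](O)[C@H]2O)c(OC)c1` from compound 2: 4-allyl-2-methoxyphenyl in place of 1-methyl-1-(4-methylcyclohex-3-en-1-yl)ethyl on an oxygen on a saturated carbon. For the measured compounds named here, no measured pair covers a change of this kind, so the guide is that compound 3, with a different aglycone of its own, still gives 95.7% in this assay, indistinguishable from the other two.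

Compound 4 is therefore expected to give about 95% in this assay, between 88% and 99%. The step of a number 0.3 percentage points lower from compound 2 to compound 4 (within the scatter) that this estimate implies is expected to stay within the scatter.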

Compound 4, a percentage reported as activity, at one concentration (the size of the read-out at that concentration, not a potency): 95.2%
For compound 4 the middle estimate is 0.2 percentage points below the measured one; measured number inside the range.
By their numbers in this assay, from the lowest: compounds 4, 2, 1 and 3 (each within the scatter of the next).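

In this assay, among the compounds shown here, the exchange of 1-methyl-1-(4-methylcyclohex-3-en-1-yl)ethyl for 4-allyl-2-methoxyphenyl on an oxygen on a saturated carbon gives the first measured step for a change of aglycone at this position: a number 0.1 percentage points lower from compound 2 to compound 4 (within the scatter), and a number 0.2 percentage points lower from compound 1 to compound 4 (within the scatter). A six-membered aromatic ring entering for a six-membered non-aromatic ring therefore leaves the read-out at the concentration tested within the scatter. The result holds from either starting compound, and the two steps can be read as one exchange for this reason: the fact that compounds 1 and 2 differ only in the configuration as drawn

All the compounds shown carry the same galloyl glucoside, so they leave open what an aglycone bearing an amine or a carboxylic acid would give. They also leave open what a glucoside without the galloyl ester would give.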